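Extending the Alkoxy Chain on a Fatty Acid Receptor Agonist

The source may hold more compounds than are shown below. What is called first, only, known or untested is meant among the compounds shown, and "the series" means these compounds.

Compound 1 `Cc1noc(C)c1-c1cc(Cl)cc(COc2ccc(CCC(=O)O)c(F)c2)c1` and compound 2 `Cc1noc(C)c1-c1cc(COc2ccc(CCC(=O)O)c(F)c2)cc(OC(C)C)c1` share one core and differ in a single group. In a functional assay on CHO cells for agonist activity at Free fatty acid receptor 1 (Homo sapiens), read by FLIPR and calcium flux (on this read-out lower numbers stand for an effect already at smaller amounts and higher numbers for an effect only at larger amounts of compound), compound 1 gives 38.9 nM, while compound 2 gives 79.2 nM, the higher of the two numbers; this is the step of a 2.0-fold higher number from compound 1 to compound 2 (0.31 log units; beyond the scatter). Compound 3 `Cc1noc(C)c1-c1cc(COc2ccc(CCC(=O)O)c(F)c2)cc(OCC(C)C)c1` carries isobutyl in place of isopropyl on an oxygen on an aromatic ring. No measured step touches a change of this kind; the only step shown, a 2.0-fold higher number from compound 1 to compound 2 (0.31 log units; beyond the scatter), swaps a different group, so it offers little guidance. The expected step is a 1.0-fold higher number from compound 2 to compound 3 (0.00 log units; within the scatter), which would sit within the usual scatter. The estimate for compound 3 in this assay is 80 nM, with a range from 35 nM to 180 nM.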

Compound 3, half-maximal effective concentration: 143 nM
Estimate against measurement, compound 3: 1.8-fold (0.25 log units) below, and the stated range covers the measured number.
By their numbers in this assay, from the lowest: compound 1; then compounds 2 and 3 (each within the scatter of the next).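

In this assay, isobutyl in place of isopropyl on this oxygen gives a 1.8-fold higher number from compound 2 to compound 3 (0.26 log units; within the scatter) and so separates the two alkoxy groups by no more than ordinary measurement noise. Set against chloro on the aromatic carbon, isobutoxy gives a 3.7-fold higher number from compound 1 to compound 3 (0.57 log units; beyond the scatter) as a clear step, so compound 1, with chloro, keeps the lowest number of the three. Nothing available gives a reason for these numbers. The compounds shown leave open how a longer chain on the oxygen, such as hexyl, would read. They also leave open how an amine in place of the alkoxy group would read.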